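Swapping the anilino group for a furanylmethylamino group

The source may hold more compounds than are shown below. What is called first, only, known or untested is meant among the compounds shown, and "the series" means these compounds.

Measured so far:
- compound 1, `CCN1CCN(c2ccc(Nc3ncc(Cl)c(Nc4ccccc4C)n3)nc2)CC1`: > 100000 nM
- compound 2, `CN1CCN(c2ccc(Nc3ncc(Cl)c(Nc4ccccc4)n3)nc2)CC1`: 37400 nM

Among the compounds with values here, in a functional assay on MDA-MB-231 cells (Homo sapiens) for inhibition, read by CCK-8 assay, with a stated time of 48 h (on this read-out higher numbers stand for weaker inhibition of growth and lower numbers for stronger inhibition of growth), compound 2 gives 37400 nM, the only actual number in this set. Compound 1 reaches only a limit of the assay, > 100000 nM, as noted in the limit of > 100000 nM in this assay, at which 1 of the 2 values shown sits. Compound 2 therefore stands as the sole reference point, and it is itself a weak inhibitor.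

Compound 3, `CN1CCN(c2ccc(Nc3ncc(Cl)c(NCc4ccco4)n3)nc2)CC1`, has not yet been tested. It differs from compound 2 in one place: (furan-2-yl)methyl in place of phenyl on a nitrogen on an aromatic ring. Within the data shown here, with no measured step of this kind to lean on, the expectation for this assay is a small shift toward weaker inhibition, not clearly beyond the scatter. Compound 3 is thus estimated at 50000 nM, with a range from 15000 nM to 150000 nM. The implied step a 1.3-fold higher number from compound 2 to compound 3 (0.13 log units; within the scatter) is expected to be modest, and a limit rather than a number would not be surprising.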

Compound 3, concentration for 50% growth inhibition: 11000 nM
Compound 3: middle estimate off by 4.5-fold (0.66 log units), on the high side; the measured number lies below the stated range.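

Within the data shown here, replacing anilino with ((furan-2-yl)methyl)amino gives a 3.4-fold lower number from compound 2 to compound 3 (0.53 log units; beyond the scatter) in this assay, so this place, on a nitrogen on an aromatic ring, responds to a change of group, which the earlier compounds could not show. The anilino group is therefore not needed for the growth inhibition seen in this assay, although compound 3, at 11000 nM, remains a weak inhibitor. Nothing given here accounts for the step, and the ring and its methyl link changed together, so their separate contributions cannot be told apart.

Going by these compounds, it remains open whether benzyl, which would keep the phenyl ring and add the methyl link, would give a similar number. On these data alone, it is equally open whether the furan ring itself matters, as (thiophen-2-yl)methyl or (tetrahydrofuran-2-yl)methyl at this place could show.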